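The source may hold more compounds than are shown below. What is called first, only, known or untested is meant among the compounds shown, and "the series" means these compounds.

Compound 3 `COc1ccc(C2=C(c3cc(OC)c(OC)c(OC)c3)C(=O)C(O)C2)cc1F` carries a hydroxy group on its saturated ring. In an ADME assay on HEp-2 cells (Homo sapiens) for cytotoxicity, read by MTT assay, with a stated time of 72 h (on this read-out lower numbers stand for stronger inhibition and higher numbers for weaker inhibition), compound 3 gives < 1 ug/mL, which is a limit of the assay rather than a number. Compound 1 `COc1ccc(C2=C(c3cc(OC)c(OC)c(OC)c3)C(=O)C(OC(C)=O)C2)cc1F` differs from compound 3 by acetyl in place of hydrogen on an oxygen on a saturated carbon. In this assay compound 1 gives < 1 ug/mL, again a limit. Accordingly a step that the two limits leave unreadable from compound 3 to compound 1. Compound 2 `COc1ccc(C2=C(c3cc(OC)c(OC)c(OC)c3)C(=O)C(O)C2)cc1Cl` differs from compound 3 by chloro in place of fluoro on an aromatic carbon. In this assay compound 2 gives < 1 ug/mL, also a limit. Hence a step that the two limits leave unreadable from compound 2 to compound 3. All three values rest at the limit of < 1 ug/mL in this assay, at which 3 of the 3 values shown sit, so none of the three compounds can be ordered against the others.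

Compound 4 `COc1ccc(C2=C(c3cc(OC)c(OC)c(OC)c3)C(=O)C(OC(C)=O)C2)cc1Cl` is not yet measured. It differs from compound 2 by acetyl in place of hydrogen on an oxygen on a saturated carbon, the same change made from compound 3 to compound 1, at a place described in the same words. Because every measured neighbour sits at the limit of < 1 ug/mL in this assay, at which 3 of the 3 values shown sit, the step from compound 2 to compound 4 in this assay is expected to be a step that the limit leaves unreadable from compound 2 to compound 4, beside the unreadable earlier one. For compound 4 the expected value in this assay is 0.5 ug/mL, from 0.1 ug/mL to 1.5 ug/mL.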

Compound 4, half-maximal inhibitory concentration: < 1 ug/mL
Compound 4 ended at the assay's limit; the forecaster's own chance of this, stated with the estimate: 80%; the middle value is on the limit's open side.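

In this assay compound 4 gives < 1 ug/mL, which is a limit of the assay. Its steps from compound 2 and from compound 1 cannot be read, so this result yields no new step: the limit of < 1 ug/mL in this assay, at which 4 of the 4 values shown sit.

The compounds shown leave open how the four compare, and whether acetyl in place of hydrogen or chloro in place of fluoro shifts the value at all.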